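Compound 2 to compound 3: a fluoro exchange

The source may hold more compounds than are shown below. What is called first, only, known or untested is meant among the compounds shown, and "the series" means these compounds.

Measured in a functional assay on K562 cells (Homo sapiens) for inhibition, read by MTT assay, with a stated time of 72 h; a lower number here means a stronger inhibitor of growth, a higher number a weaker inhibitor of growth:
- compound 1 `Nc1n[nH]c2cccc(C#Cc3cccc(NC(=O)c4cccc(C(F)(F)F)c4)c3)c12`: 1540 nM
- compound 2 `Cc1cn(-c2cc(C(=O)Nc3cccc(C#Cc4cccc5[nH]nc(N)c45)c3)cc(C(F)(F)F)c2)cn1`: 70 nM

Compound 2 holds the lower of these two numbers, and the gap to compound 1 lies beyond the scatter. The next structure is compound 3 `Nc1n[nH]c2cccc(C#Cc3cccc(NC(=O)c4cc(F)cc(C(F)(F)F)c4)c3)c12`, and the change is fluoro in place of 4-methyl-1H-imidazol-1-yl on an aromatic carbon, meta to a trifluoromethyl group.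

For the measured compounds named here, one measured step bears on this. It is a 22-fold lower number from compound 1 to compound 2 (1.34 log units; beyond the scatter), large, with 4-methyl-1H-imidazol-1-yl in place of hydrogen on that carbon. Going by the values given here, compound 3 carries fluoro where compound 1 carries hydrogen, and no measurement yet shows how fluoro compares with hydrogen there. Most of that step is therefore expected to reverse in this assay, giving a large move to a higher number. The expected size is a 14-fold higher number from compound 2 to compound 3 (1.15 log units; beyond the scatter). For compound 3 the estimated value is 1000 nM, with an expected range of 350 nM to 3000 nM.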

Compound 3, concentration for 50% growth inhibition: 2140 nM
Estimate against measurement, compound 3: 2.1-fold (0.33 log units) below; the range from low to high includes it.
By their numbers in this assay, from the lowest: compound 2; then compounds 1 and 3 (each within the scatter of the next).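

In this assay, fluoro in place of 4-methyl-1H-imidazol-1-yl gives a 31-fold higher number from compound 2 to compound 3 (1.49 log units; beyond the scatter), so the gain at this carbon does not survive when a single fluorine takes the place of the ring. Fluoro in place of hydrogen gives a 1.4-fold higher number from compound 1 to compound 3 (0.14 log units; within the scatter), which lies within the scatter, so this assay does not separate these two small substituents. Nothing available explains why these groups differ at this position.

The compounds shown leave open whether the low number of compound 2 requires the whole 4-methyl-1H-imidazol-1-yl group or only part of it. An imidazole without the methyl, or a non-aromatic group such as a dimethylamino group or a morpholine on the same carbon, would bear on that question.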